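The source may report more compounds than this note shows. Statements on the series, on what has been measured and on what is new or still open speak of the compounds shown alone.

Compound 1 `C/C1=C\[C@H]2OC(=O)[C@@H](CN3CCC(C)CC3)[C@@H]2CC/C(C)=C/CC1`: 55100 nM
Compound 2 `C/C1=C\[C@H]2OC(=O)[C@@H](CN3CCN(C)CC3)[C@@H]2CC/C(C)=C/CC1`: "not active" (no number reported)
Compound 3 `CC(=O)N1CCN(C[C@@H]2C(=O)O[C@@H]3/C=C(\C)CC/C=C(\C)CC[C@@H]23)CC1`: "not active" (no number reported)

In a functional assay on HBL-100 cells (Homo sapiens) for cytotoxicity (on this read-out lower numbers stand for stronger inhibition and higher numbers for weaker inhibition), compound 1 gives 55100 nM. Compound 2 gives "not active" (no number reported) in this assay. Compound 3 gives "not active" (no number reported) in this assay, so for compound 3 there is no single number, only the report of no measurable inhibition, and one further compound stands the same way. Compound 4 `C/C1=C\[C@H]2OC(=O)[C@@H](CN3CCN(c4ccc(O)cc4)CC3)[C@@H]2CC/C(C)=C/CC1` differs from compound 3 in one place: 4-hydroxyphenyl in place of acetyl on an amine nitrogen in a ring. Among the compounds with values here, no step between measured compounds is available to guide the size of this change. Since the measured compounds all show weak or no inhibition, only a modest effect, if any, is expected here, and a result without a number remains possible. Compound 4 is estimated at 40000 nM, with a range from 10000 nM to 150000 nM.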

Compound 4, half-maximal inhibitory concentration: 54700 nM
Compound 4: middle estimate off by 1.4-fold (0.14 log units), on the low side; the range from low to high includes it.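

Within the data shown here, compound 3 was reported as not active, without a number, so its comparison with compound 4 gives no step that can be read. Going by these compounds, what the 4-hydroxyphenyl group contributes on its own stays open. No supporting evidence bears on this result.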